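A few compounds are considered here, and "the series" means these few. Any claim that something is new, unique, unknown or untested is made for them only; others in the source may bear on it.

Compound 1 `Oc1ccccc1-c1cc(-c2ccccc2C(F)(F)F)cc(-c2ccccc2O)n1` has a shared core bearing two 2-hydroxyphenyl groups and a 2-(trifluoromethyl)phenyl group. In a functional assay on HeLa cells (Homo sapiens) for inhibition (on this read-out higher numbers stand for weaker inhibition and lower numbers for stronger inhibition), compound 1 gives 5800 nM. Compound 2 `Oc1ccccc1-c1cc(-c2cccc(C(F)(F)F)c2)cc(-c2ccccc2O)n1` differs from it in a single place, (3-(trifluoromethyl)phenyl in place of 2-(trifluoromethyl)phenyl on an aromatic carbon). For compound 2 this assay reports only a limit, > 50000 nM, which is not a number. The step that this change made is an at least 8.6-fold higher number from compound 1 to compound 2 (0.93 log units; beyond the scatter), and how far it really went is hidden by the limit of > 50000 nM in this assay, at which 1 of the 3 values shown sits.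

Compound 3 `Oc1cccc(-c2cc(-c3ccccc3C(F)(F)F)cc(-c3cccc(O)c3)n2)c1` carries the same 2-(trifluoromethyl)phenyl group but 3-hydroxyphenyl groups on the core; the difference between the two cores is not broken down here. In this assay compound 3 gives 15200 nM, the higher of the two numbers that are not limits, with compound 1 nearest to it.

Compound 4 `Oc1cccc(-c2cc(-c3cccc(C(F)(F)F)c3)cc(-c3cccc(O)c3)n2)c1` has not yet been measured. It differs from compound 3 by 3-(trifluoromethyl)phenyl in place of 2-(trifluoromethyl)phenyl on an aromatic carbon. This is the same kind of change as from compound 1 to compound 2, though the surroundings differ: in compound 3 the place is meta to two 3-hydroxyphenyl groups, while in compound 1 it is meta to two 2-hydroxyphenyl groups. A step of the same direction, a 5.9-fold higher number from compound 3 to compound 4 (0.77 log units; beyond the scatter), is expected for compound 4 because the earlier move gave an at least 8.6-fold higher number from compound 1 to compound 2 (0.93 log units; beyond the scatter). Starting from the higher number of compound 3, compound 4 is therefore estimated at 90000 nM, between 30000 nM and 300000 nM, and this assay may well report only a limit for it.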

Compound 4, half-maximal inhibitory concentration: 12700 nM
Compound 4: the middle estimate sits 7.1-fold (0.85 log units) above what was measured; measured number outside the range, below it.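

In this assay, replacing 2-(trifluoromethyl)phenyl with 3-(trifluoromethyl)phenyl gives a 1.2-fold lower number from compound 3 to compound 4 (0.08 log units; within the scatter), so on the core of compound 3 the change has no effect that can be told from ordinary scatter. This shows that the result of the change on one core cannot simply be carried over to the other in this series, as the two steps differ: the same change on two cores in this assay, an at least 8.6-fold higher number (0.93 log units; beyond the scatter) from compound 1 to compound 2 and a 1.2-fold lower number (0.08 log units; within the scatter) from compound 3 to compound 4, at least 10-fold (1.01 log units) apart, beyond the scatter of two such steps. It does not show why the two cores respond differently, and the full size of the step to compound 2 also stays unknown, since that compound has only a limit: the limit of > 50000 nM in this assay, at which 1 of the 4 values shown sits.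

The compounds shown leave open how the same change would behave on any further core, since two cores cannot reveal a general rule. They also leave open whether the result is tied to the trifluoromethyl group or to the hydroxy groups, for example whether a nitrile in place of the trifluoromethyl group, or a methoxy group or an amine in place of the hydroxy groups, would give the same contrast between the two cores.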